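A few compounds are considered here, and "the series" means these few. Any claim that something is new, unique, unknown or untested is made for them only; others in the source may bear on it.

Measured compounds:
- compound 1 `Cc1ccc(CNC(=O)c2cccc(C(C)Oc3cccnc3Nc3cnn(CC(C)(C)O)c3)c2)cc1`: 20500 nM in a functional assay on HCC78 cells (Homo sapiens) for antiproliferative activity, read by MTT assay, with a stated time of 48 h; on this read-out lower numbers stand for stronger inhibition and higher numbers for weaker inhibition
- compound 2 `Cc1ccc(CNC(=O)c2cccc(C(C)Oc3cccnc3Nc3nncs3)c2)cc1`: 17600 nM
- compound 3 `COc1cccc(CNC(=O)c2cccc(C(C)Oc3ccnc(Nc4cnn(C)c4)c3)c2)c1`: 64400 nM

Compound 3 stands highest of the three numbers in this assay; compound 1 and compound 2 both give lower numbers, and both gaps lie beyond the scatter. Among the measured compounds shown here, compound 3 differs from the other two in more than one place, so no single step connects it to them.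

The next compound is compound 4 `COc1cc(CNC(=O)c2cccc(C(C)Oc3ccnc(Nc4cnn(C)c4)c3)c2)cc(OC)c1OC`, which differs from compound 3 as 3,4,5-trimethoxyphenyl in place of 3-methoxyphenyl on a saturated chain carbon bound to an amide-type nitrogen. For the measured compounds named here, the only measured single step, a 1.2-fold lower number from compound 1 to compound 2 (0.07 log units; within the scatter), changes the group on a nitrogen on an aromatic ring at the other end of the molecule and is within the scatter. Going by the values given here, no measured step changes the aryl on the saturated chain carbon bound to the amide-type nitrogen, so nothing in the data speaks directly to this change. On that basis no step beyond the scatter is expected in this assay, in either direction.

For compound 4 the expected value is 60000 nM, with a range from 20000 nM to 180000 nM. This estimate corresponds to an expected step of a 1.1-fold lower number from compound 3 to compound 4 (0.03 log units; within the scatter).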

Compound 4, half-maximal inhibitory concentration: 73900 nM
Compound 4: the middle estimate sits 1.2-fold (0.09 log units) below what was measured; the range from low to high includes it.
By their numbers in this assay, from the lowest: compounds 2 and 1 (each within the scatter of the next); then compounds 3 and 4 (each within the scatter of the next).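

In this assay, among the compounds shown here, the step of a 1.1-fold higher number from compound 3 to compound 4 (0.06 log units; within the scatter) is the first measured change at this position, a saturated chain carbon bound to an amide-type nitrogen. It shows that 3,4,5-trimethoxyphenyl can stand in place of 3-methoxyphenyl here with no shift beyond the scatter, even though the entering group carries more heavy atoms and more hydrogen-bond acceptors. With the methoxy-substituted aryl groups tested on this core, the read-out therefore does not respond to the added methoxy groups, and no information is available that explains this result.

On these data alone, two methoxy-substituted aryl groups cover only a narrow part of what this position could hold, so it remains open whether the flat result extends to a different kind of group there, such as a phenyl ring carrying a carboxylic acid or a dimethylamino group, or a longer chain ahead of the aryl. As far as these compounds go, it also remains open whether the same change would behave alike on the core of compound 1 or compound 2, which differs from that of compound 3 in more than one place.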